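Methoxy for Amino on the Ketone-Side Ring

A few compounds are considered here, and "the series" means these few. Any claim that something is new, unique, unknown or untested is made for them only; others in the source may bear on it.

Compound 1, `COc1cc(-c2cc(/C=C/C(=O)c3ccc(N)cc3)[nH]n2)cc(OC)c1OC`, was tested in a functional assay on RPMI-8226 cells (Homo sapiens) for cytotoxicity, read by sulforhodamine B assay, with a stated time of 48 h, tested at 10 uM (a higher number here means a weaker effect of the compound at the concentration tested, a lower number a stronger effect), and gives -35%. Among the three measured compounds it stands second highest: compound 3, `COc1ccc(-c2cc(/C=C/C(=O)c3cc(OC)c(OC)c(OC)c3)[nH]n2)cc1OC`, gives -38%, within the scatter of compound 1, while compound 2, `COc1ccc(-c2cc(/C=C/C(=O)c3ccc(N)cc3)[nH]n2)cc1OC`, gives -20%, which lies beyond it. Among the measured compounds shown here, the one single-place step known is a number 15 percentage points higher from compound 1 to compound 2 (beyond the scatter), a modest move on removing a methoxy group from the shared core.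

Compound 4, `COc1ccc(C(=O)/C=C/c2cc(-c3cc(OC)c(OC)c(OC)c3)n[nH]2)cc1`, differs from compound 1 by methoxy in place of amino on an aromatic carbon. For the measured compounds named here, no measured step carries this exact change. Compound 2 and compound 3 differ at the same ketone-side ring, but in more than one place, so their values only show that a methoxy-bearing ring there is compatible with a number close to that of compound 1. Going by the values given here, with no direct precedent, a step of no size beyond the scatter, a number 5 percentage points higher from compound 1 to compound 4 (within the scatter), is expected, and compound 4 is estimated at -30% with a range from -50% to -10%.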

Compound 4, a percentage reported as activity, at one concentration (the size of the read-out at that concentration, not a potency): -41%
Compound 4: the middle estimate sits 11 percentage points above what was measured, and the stated range covers the measured number.
By their numbers in this assay, from the lowest: compounds 4, 3 and 1 (each within the scatter of the next); then compound 2.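

At the ketone-side ring, the change from 4-aminophenyl to 4-methoxyphenyl gives a number 6 percentage points lower from compound 1 to compound 4 (within the scatter) in this assay on the core of compound 1. Among the compounds shown here, this is the first direct reading at this position, and it shows that, for this pair, the amino group and the hydrogen-bond donor it carries are not required for a number in this range. Nothing shown accounts for this result in terms of mechanism or of any measured property.

As far as these compounds go, whether a hydroxy group, a dimethylamino group or a carboxylic acid on the same aromatic carbon would give a similar number remains open. From the compounds shown here alone, it is also open whether the same exchange would read the same way on the core of compound 2, which carries one methoxy group fewer.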